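Swapping Cyclopropyl for 3-Chlorophenyl on the Shared Core

The source may report more compounds than this note shows. Statements on the series, on what has been measured and on what is new or still open speak of the compounds shown alone.

Compound 1 `O=S(=O)(Nc1ccc(F)c(C#Cc2cnc3[nH]ncc3c2)c1F)c1ccccc1F` and compound 2 `O=S(=O)(Nc1ccc(F)c(C#Cc2cnc3[nH]nc(C4CC4)c3c2)c1F)c1cccnc1` were measured in a functional assay on HCT-116 cells (Homo sapiens) for antiproliferative activity, read by MTT assay, with a stated time of 68 h; on this read-out higher numbers stand for weaker inhibition and lower numbers for stronger inhibition. In this assay compound 1 reaches only a limit, > 10000 nM. Compound 2 gives 584 nM, the only number shown. The other value shown, that of compound 1, is a limit (the limit of > 10000 nM in this assay, at which 1 of the 2 values shown sits). Compound 3 `O=S(=O)(Nc1ccc(F)c(C#Cc2cnc3[nH]nc(-c4cccc(Cl)c4)c3c2)c1F)c1cccnc1` differs from compound 2 by 3-chlorophenyl in place of cyclopropyl on an aromatic carbon. For the measured compounds named here, no step between measured compounds is given, so the size of this step is open; a change within the usual scatter is expected, with a step from compound 2 to compound 3 of a 1.3-fold lower number from compound 2 to compound 3 (0.11 log units; within the scatter). Compound 3 is therefore estimated at 450 nM, between 120 nM and 2000 nM.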

Compound 3, half-maximal inhibitory concentration: > 10000 nM
Compound 3 was reported as a limit (the forecaster's own chance of this, stated with the estimate: 8%); at least 22-fold (1.34 log units) between middle value and limit.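

In this assay, this position on an aromatic carbon of the five-membered ring does not tolerate every group equally: 3-chlorophenyl in place of cyclopropyl gives an at least 17-fold higher number from compound 2 to compound 3 (1.23 log units; beyond the scatter) and moves the result beyond the scatter. The value of compound 3 is a limit, so the full size of this step cannot be read, and it joins the other limit: the limit of > 10000 nM in this assay, at which 2 of the 3 values shown sit.

The compounds shown leave open whether an unsubstituted phenyl would behave like 3-chlorophenyl or like cyclopropyl. They also leave open how a methyl or an amine would fare at this position.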